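The source may report more compounds than this note shows. Statements on the series, on what has been measured and on what is new or still open speak of the compounds shown alone.

Three compounds have been measured in a functional assay on BXPC-3 cells (Homo sapiens) for antiproliferative activity, read by MTT assay, with a stated time of 24 h; a higher number here means a weaker inhibitor, a lower number a stronger inhibitor:

Compound 1 `CCn1c(C(=O)NCCN)ccc1C(CC)(CC)c1ccc(OCS(=O)(=O)c2ccccc2)c(C)c1`: 6430 nM
Compound 2 `CCn1c(C(=O)N[C@@H](CO)C(C)C)ccc1C(CC)(CC)c1ccc(OCS(=O)(=O)c2ccccc2)c(C)c1`: 13200 nM
Compound 3 `CCn1c(C(=O)N[C@H](C)C(=O)O)ccc1C(CC)(CC)c1ccc(OCS(=O)(=O)c2ccccc2)c(C)c1`: 20100 nM

All three share one core and differ only in the group on the amide-type nitrogen. The position of compound 3 rests on two steps: a 3.1-fold higher number from compound 1 to compound 3 (0.49 log units; beyond the scatter), and a 1.5-fold higher number from compound 2 to compound 3 (0.18 log units; within the scatter). It therefore lies clearly apart from compound 1 but cannot be told apart from compound 2.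

Compound 4 `CCn1c(C(=O)N[C@H](CC(=O)O)C(=O)O)ccc1C(CC)(CC)c1ccc(OCS(=O)(=O)c2ccccc2)c(C)c1` is not yet measured. It carries carboxy in place of hydrogen on a saturated chain carbon, two bonds along the chain from an amide-type nitrogen and a carbonyl carbon, turning 1-carboxyethyl into 1,2-dicarboxyethyl: carboxy in place of hydrogen on a saturated chain carbon, two bonds along the chain from an amide-type nitrogen and a carbonyl carbon.

Going by the values given here, no measured step adds a second carboxy, so the evidence is indirect. Putting 1-carboxyethyl in place of 2-aminoethyl gave a modest step, a 3.1-fold higher number from compound 1 to compound 3 (0.49 log units; beyond the scatter), while the other step into compound 3 stayed within the scatter, a 1.5-fold higher number from compound 2 to compound 3 (0.18 log units; within the scatter). A small change in this assay is therefore expected, leaning toward a higher number and probably not beyond the scatter. The expected step is a 1.2-fold higher number from compound 3 to compound 4 (0.09 log units; within the scatter). The estimate for compound 4 is 25000 nM, with an expected range from 11000 nM to 55000 nM.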

Compound 4, half-maximal inhibitory concentration: > 50000 nM
Compound 4 ended at the assay's limit (the forecaster's own chance of this, stated with the estimate: 10%); middle value at least 2.0-fold (0.30 log units) from the limit.
By their numbers in this assay, from the lowest: compound 1; then compounds 2 and 3 (each within the scatter of the next). At a limit, above all of these: compound 4.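

In this assay compound 4 gives a limit of the assay and not a number: the limit of > 50000 nM in this assay, at which 1 of the 4 values shown sits.

Compound 1, compound 2 and compound 3 differ by the whole group on the amide-type nitrogen, whereas this change adds only carboxy in place of hydrogen on a saturated chain carbon, two bonds along the chain from an amide-type nitrogen and a carbonyl carbon, and it gives an at least 2.4-fold higher number from compound 3 to compound 4 (0.39 log units; beyond the scatter), so this position does respond to a single added group. The 1,2-dicarboxyethyl group also stands clearly apart from the two other groups, with an at least 3.7-fold higher number from compound 2 to compound 4 (0.57 log units; beyond the scatter) and an at least 7.7-fold higher number from compound 1 to compound 4 (0.89 log units; beyond the scatter), although 1-carboxyethyl could not be told apart from 1-(hydroxymethyl)-2-methylpropyl.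

On these data alone, since the reading is a limit, the true size of all three steps stays open. As far as these compounds go, it also remains open whether a methyl ester, a primary amide or a hydroxymethyl group at this place would act as carboxy does, and whether a longer chain carrying the carboxylic acid would behave the same way.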